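Amide substituent and solubility: from compound 3 to compound 4

This account rests on a few compounds, and the source may have more. Where it says the series, first, only, none or still open, it means among the compounds named here.

compound 1 `CCNC(=O)c1nc(-c2ccc(CN(C)C)cc2)cnc1N`: > 1000000 nM (a limit of the assay)
compound 2 `CN(C)Cc1ccc(-c2cnc(N)c(C(=O)NC[C@@](C)(O)C(F)(F)F)n2)cc1`: 510000 nM
compound 3 `CN(C)Cc1ccc(-c2cnc(N)c(C(=O)NCC(O)C(F)(F)F)n2)cc1`: 880000 nM

In a physicochemical assay for solubility, at pH 6.8 (on this read-out higher numbers stand for higher solubility and lower numbers for lower solubility), compound 1 gives > 1000000 nM, which is a limit of the assay and not a number. Compound 2 gives 510000 nM and compound 3 gives 880000 nM; the two lie within the scatter of each other, as a 1.7-fold higher number from compound 2 to compound 3 (0.24 log units; within the scatter) shows. Compound 4 `CC(C)NC(=O)c1nc(-c2ccc(CN(C)C)cc2)cnc1N` carries isopropyl in place of 3,3,3-trifluoro-2-hydroxypropyl on an amide-type nitrogen. The closest comparison is an at least 1.1-fold lower number from compound 1 to compound 3 (0.05 log units; that floor lies within the scatter), run the other way, and it is bounded by the limit of > 1000000 nM in this assay, at which 1 of the 3 values shown sits, so its size is only a floor. The expected step of a 1.1-fold higher number from compound 3 to compound 4 (0.03 log units; within the scatter) is a modest rise, with a fair chance that compound 4 again reaches the limit. Compound 4 is estimated at 950000 nM, between 450000 nM and 1000000 nM.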

Compound 4, solubility: > 1000000 nM
Compound 4 gave a limit, no number; the forecaster's own chance of this, stated with the estimate: 40%; at least 1.0-fold (0.02 log units) between middle value and limit.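

In this assay compound 4 gives a limit and not a number, as compound 1 does: the limit of > 1000000 nM in this assay, at which 2 of the 4 values shown sit. With isopropyl on the amide-type nitrogen, only floors can be read, an at least 1.1-fold higher number from compound 3 to compound 4 (0.05 log units; that floor lies within the scatter) and an at least 1.9-fold higher number from compound 2 to compound 4 (0.29 log units; that floor lies within the scatter), so neither replacement of a hydroxylated, fluorinated chain is shown to go beyond the scatter. The step between compound 1 and compound 4 cannot be read, so methyl in place of hydrogen on this chain has no readable size.

As far as these compounds go, how far compound 1 and compound 4 lie past the limit remains open. So does the reading for a longer chain such as n-butyl, or a chain bearing a carboxylic acid.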